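The source may hold more compounds than are shown below. What is called first, only, known or untested is meant among the compounds shown, and "the series" means these compounds.

Compound 1 `COc1ccc(-c2c(C)nn(-c3nc(-c4ccc(Cl)c(Cl)c4)c(SC(C)C)s3)c2C(=O)O)cc1` sits at the lowest of the three numbers measured in a functional assay on BJAB cells (Homo sapiens) for antiproliferative activity, with a stated time of 4 days (a lower number here means that less compound is needed, a higher number that more compound is needed for the effect), where compound 1 gives 2100 nM. Two neighbours have been measured that differ from it in one place. Compound 2 `Cc1nn(-c2nc(-c3ccc(Cl)c(Cl)c3)c(SC(C)C)s2)c(C(=O)O)c1Cc1ccccc1[N+](=O)[O-]` gives 20000 nM, and the change is a 9.5-fold higher number from compound 1 to compound 2 (0.98 log units; beyond the scatter). Compound 3 `Cc1nn(-c2nc(-c3ccc(Cl)c(Cl)c3)c(SC(C)C)s2)c(C(=O)O)c1-c1cc(C#N)cc(C(F)(F)F)c1` gives 3600 nM, and the change is a 1.7-fold higher number from compound 1 to compound 3 (0.23 log units; within the scatter). Between these two, compound 2 and compound 3 differ by a 5.6-fold lower number from compound 2 to compound 3 (0.74 log units; beyond the scatter).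

Compound 4 `COc1cc(-c2c(C)nn(-c3nc(-c4ccc(Cl)c(Cl)c4)c(SC(C)C)s3)c2C(=O)O)cc(C(F)(F)F)c1` has not yet been measured. It differs from compound 1 in one place: 3-methoxy-5-(trifluoromethyl)phenyl in place of 4-methoxyphenyl on an aromatic carbon. Going by the values given here, of the measured steps, the one from compound 1 to compound 3 bears most on this, since it also replaces the 4-methoxyphenyl with a six-membered aromatic ring carrying a trifluoromethyl group and a second substituent, and it stayed within the scatter. The step to compound 2, which instead brings in a 2-nitrobenzyl group, is less comparable. The expectation is therefore a small step, if any, toward a higher number. Compound 4 is expected to give about 3000 nM in this assay, within a range from 1200 nM to 7500 nM. That expected change corresponds to a 1.4-fold higher number from compound 1 to compound 4 (0.15 log units; within the scatter).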

Compound 4, half-maximal effective concentration: 1380 nM
Beside the measured number, compound 4's estimate is 2.2-fold (0.34 log units) above it, and the stated range covers the measured number.
By their numbers in this assay, from the lowest: compounds 4, 1 and 3 (each within the scatter of the next, the first and the last beyond it); then compound 2.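

In this assay the position on the five-membered aromatic ring that holds the phenyl group accepts the larger 3-methoxy-5-(trifluoromethyl)phenyl, with a 1.5-fold lower number from compound 1 to compound 4 (0.18 log units; within the scatter). The new compound also shows that the second substituent on this ring can matter: with the trifluoromethyl group kept, methoxy in place of cyano gives a 2.6-fold lower number from compound 3 to compound 4 (0.42 log units; beyond the scatter), a difference that the comparison of compound 1 and compound 3 alone did not reveal. Replacing the 2-nitrobenzyl group with this directly attached ring gives a 14-fold lower number from compound 2 to compound 4 (1.16 log units; beyond the scatter), so compound 2 remains apart from the three compounds that carry a phenyl ring directly on this position.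

No available evidence explains why these numbers differ. The compounds shown leave open whether an amine or a hydroxy group in place of the methoxy would keep the number this low, and whether the trifluoromethyl group is needed at all, since a ring bearing methoxy and nitrile together would test that directly.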